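Taking the hydroxy group off compound 2

The compounds below may be only part of what the source reports. "The series", "measured", "known", "first", "only" and "open" are said of these compounds alone.

In a functional assay on KBVIN cells (Homo sapiens) for antiproliferative activity, read by sulforhodamine B assay, with a stated time of 3 days (a lower number here means that less compound is needed, a higher number that more compound is needed for the effect), compound 1 `CCC1=C(O)c2c(oc(-c3ccc(CBr)cc3)cc2=O)C(CC)(CC)C1=O` gives 27.9 uM and compound 2 `CCC1=C(O)c2c(oc(-c3cc(C)c(O)c(C)c3)cc2=O)C(CC)(CC)C1=O` gives 8.9 uM, the lower of the two numbers. Compound 3 `CCC1=C(O)c2c(oc(-c3cc(C)cc(C)c3)cc2=O)C(CC)(CC)C1=O` has not yet been measured. It differs from compound 2 in one place: hydrogen in place of hydroxy on an aromatic carbon. In words, this is hydrogen in place of hydroxy on an aromatic carbon, so 4-hydroxy-3,5-dimethylphenyl becomes 3,5-dimethylphenyl. Among the measured compounds shown here, only one measured step bears on this, a 3.1-fold lower number from compound 1 to compound 2 (0.50 log units; beyond the scatter). That step is modest, and it exchanged the whole group, so it says little about the hydroxy alone. For the measured compounds named here, no measured pair isolates the hydroxy, so only a small rise in the number is expected, a 1.3-fold higher number from compound 2 to compound 3 (0.13 log units; within the scatter), which may not exceed the scatter. For compound 3 the estimated value in this assay is 12 uM, with an expected range from 5 uM to 28 uM.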

Compound 3, concentration for half-maximal effect: 0.45 uM
Estimate against measurement, compound 3: 27-fold (1.43 log units) above, outside the stated range (below it).
By their numbers in this assay, from the lowest: compound 3; then compound 2; then compound 1.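

In this assay, taking off the hydroxy alone gives a 20-fold lower number from compound 2 to compound 3 (1.30 log units; beyond the scatter), so this single change on the aromatic ring, at the carbon para to a large group, matters far more than the earlier whole-group exchange could reveal. Set against 4-(bromomethyl)phenyl, 3,5-dimethylphenyl gives a 62-fold lower number from compound 1 to compound 3 (1.79 log units; beyond the scatter), much larger than a 3.1-fold lower number from compound 1 to compound 2 (0.50 log units; beyond the scatter) seen with the hydroxy still present, so the hydroxy had masked most of the gain. No measurement shown explains why the number falls so sharply with the hydroxy gone.

On these data alone, whether any other group at this carbon would give a number like that of compound 3 stays open, and a methoxy group, a fluorine or an amine there would test it. Also open, as far as these compounds go, is what the two methyl groups contribute, which ethyl groups in their place would begin to show.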